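The source may report more compounds than this note shows. Statements on the series, on what has been measured and on what is new or still open speak of the compounds shown alone.

Compound 2 `Cc1nn(-c2ccccc2)cc1/C=N/Nc1nc(Nc2ccccc2)nc(Nc2ccc(S(N)(=O)=O)cc2)n1` and compound 1 `NS(=O)(=O)c1ccc(Nc2nc(N/N=C/c3ccc(C(F)(F)F)cc3)nc(Nc3ccccc3)n2)cc1` share one core and differ only in the group attached to the carbon with a double bond to nitrogen. In a functional assay on MCF7 cells (Homo sapiens) for inhibition, read by sulforhodamine B assay, with a stated time of 48 h (on this read-out lower numbers stand for stronger inhibition of growth and higher numbers for weaker inhibition of growth), compound 2 gives 1550 nM and compound 1 gives 2180 nM, which amounts to a 1.4-fold lower number from compound 1 to compound 2 (0.15 log units; within the scatter). Compound 3 `NS(=O)(=O)c1ccc(Nc2nc(N/N=C/c3ccccn3)nc(Nc3ccccc3)n2)cc1` carries pyridin-2-yl in place of 3-methyl-1-phenyl-1H-pyrazol-4-yl on a carbon with a double bond to nitrogen. Because a 1.4-fold lower number from compound 1 to compound 2 (0.15 log units; within the scatter) swapped an aromatic group at this same carbon with hardly any effect, the new swap is expected to leave this assay essentially unchanged, an estimated step of a 1.2-fold higher number from compound 2 to compound 3 (0.06 log units; within the scatter). Compound 3 is therefore estimated at 1800 nM, with a range from 700 nM to 4500 nM.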

Compound 3, concentration for 50% growth inhibition: 1100 nM
Compound 3: middle estimate off by 1.6-fold (0.21 log units), on the high side, and the stated range covers the measured number.
By their numbers in this assay, from the lowest: compounds 3, 2 and 1 (each within the scatter of the next).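

Replacing the larger group with pyridin-2-yl at this carbon, which brings a single six-membered aromatic ring with a hetero atom, stays within the scatter (a 1.4-fold lower number from compound 2 to compound 3 (0.15 log units; within the scatter)). The same holds against the 4-(trifluoromethyl)phenyl group (a 2.0-fold lower number from compound 1 to compound 3 (0.30 log units; within the scatter)). This position therefore accepts a ring nitrogen and a much smaller aromatic group in this assay without a readable shift, and nothing given here accounts for that result. As far as these compounds go, whether a cyclohexyl group, a morpholine or a carboxylic acid on the ring would also fit here stays open.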